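This account rests on a few compounds, and the source may have more. Where it says the series, first, only, none or still open, it means among the compounds named here.

Of the compounds shown here, two have been measured in a functional assay on HT-29 cells (Homo sapiens) for cytotoxicity, read by fluorescence and sulforhodamine B assay; a higher number here means a weaker inhibitor, a lower number a stronger inhibitor. Compound 1 `COc1ccc(/C=C/Cc2ccc(O)c(OC)c2OC)cc1O` gives 41100 nM in this assay, and compound 2 `O=C1C=C[C@](O)(C/C=C/c2ccccc2)CC1` gives 19700 nM, the lower of the two numbers; the gap to compound 1 lies beyond the usual scatter, so compound 2 is the stronger inhibitor of the pair. Compound 3 `COc1ccccc1/C=C/C[C@@]1(O)C=CC(=O)CC1` has not yet been measured. It differs from compound 2 in one place: methoxy in place of hydrogen on an aromatic carbon, on an aromatic carbon of a six-membered aromatic ring of carbon only. Within the data shown here, with no comparable step among the measured compounds, no change beyond the scatter is expected, so the estimated step is a 1.1-fold lower number from compound 2 to compound 3 (0.04 log units; within the scatter). Compound 3 is expected to give 18000 nM in this assay, within a range from 7000 nM to 45000 nM.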

Compound 3, half-maximal inhibitory concentration: 17800 nM
For compound 3 the middle estimate is 1.0-fold (0.00 log units) above the measured one, and the stated range covers the measured number.
By their numbers in this assay, from the lowest: compounds 3 and 2 (each within the scatter of the next); then compound 1.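

In this assay, methoxy in place of hydrogen on an aromatic carbon, ortho to a large group, gives a 1.1-fold lower number from compound 2 to compound 3 (0.04 log units; within the scatter) and so stays within the scatter. This is the only step shown between compounds that differ in one place, and it shows that this position accepts methoxy with no change that can be told from the scatter. Nothing measured here bears on the reason for this result. The compounds shown leave open whether an amine or a carboxylic acid at this position would shift the number, and whether methoxy on another aromatic carbon would do so.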